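Chlorine to Methoxy on the Benzyl Group

This account rests on a few compounds, and the source may have more. Where it says the series, first, only, none or still open, it means among the compounds named here.

Three compounds share a core, as compound 1 `CCOC(=O)c1cccc(-c2n[nH]c3ccccc23)c1` shows. In a functional assay on cells (Platelet, Homo sapiens) for inhibition (on this read-out lower numbers stand for stronger inhibition and higher numbers for weaker inhibition), compound 1 gives only a limit, > 10000 nM. Compound 2 `CCOC(=O)c1ccc(-c2nn(Cc3ccc(Cl)cc3)c3ccccc23)cc1` carries a 4-chlorobenzyl group on the aromatic nitrogen. In this assay compound 2 likewise reaches only a limit, > 10000 nM. Compound 3 `CCOC(=O)c1ccc(-c2nn(Cc3ccccc3OC)c3ccccc23)cc1` carries a 2-methoxybenzyl group in the same place. In this assay compound 3 also stops at a limit, > 10000 nM. The step that the two limits leave unreadable from compound 2 to compound 3 therefore gives no size, and the whole picture so far is the limit of > 10000 nM in this assay, at which 3 of the 3 values shown sit.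

Compound 4 `CCOC(=O)c1ccc(-c2nn(Cc3cccc(OC)c3)c3ccccc23)cc1` is not yet measured. It differs from compound 2 by 3-methoxyphenyl in place of 4-chlorophenyl on a saturated chain carbon bound to an aromatic nitrogen. Among the measured compounds shown here, the only measured step bearing on this change is a step that the two limits leave unreadable from compound 2 to compound 3, which yields no readable size in either direction. For the measured compounds named here, no measured compound shows a number below the limit, so nothing in this assay points toward a gain. For compound 4 the expected value in this assay is 15000 nM, within 5000 nM to 50000 nM. The step that the limit leaves unreadable from compound 2 to compound 4 is expected to stay within the scatter.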

Compound 4, half-maximal inhibitory concentration: > 10000 nM
Compound 4: a limit, no number; the forecaster's own chance of this, stated with the estimate: 80%; the middle value does not contradict the limit.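

In this assay, among the compounds shown here, compound 4 also gives only a limit, so no step among compound 2, compound 3 and compound 4 can be read: the limit of > 10000 nM in this assay, at which 4 of the 4 values shown sit. The compounds shown leave open whether in this assay any group in this place would give a number rather than a limit.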